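The source may report more compounds than this note shows. Statements on the series, on what has been measured and on what is new or still open speak of the compounds shown alone.

In a functional assay on CWR22R cells (Homo sapiens) for antiproliferative activity, read by CCK-8 assay, with a stated time of 6 days (on this read-out lower numbers stand for stronger inhibition and higher numbers for weaker inhibition), a small set of compounds shares one core and varies the ring on an amine nitrogen. Compound 3 `C[C@@H](Cn1ccc(-c2ccc(C#N)c(Cl)c2)n1)Nc1cncnc1`, with pyrimidin-5-yl, reads > 30000 nM, which is a limit and not a number. Compound 1 `C[C@@H](Cn1ccc(-c2ccc(C#N)c(Cl)c2)n1)Nc1ccccn1`, with pyridin-2-yl, reads > 30000 nM, also a limit. Among the measured compounds shown here, compound 2 `C[C@@H](Cn1ccc(-c2ccc(C#N)c(Cl)c2)n1)Nc1ccncc1`, with pyridin-4-yl, gives 11500 nM and is the only one with a measured number. The set is bounded by the limit of > 30000 nM in this assay, at which 2 of the 3 values shown sit, so compound 3 stands at that limit with compound 1.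

Compound 4 `Cc1ccnc(N[C@@H](C)Cn2ccc(-c3ccc(C#N)c(Cl)c3)n2)n1` changes the ring again: 4-methylpyrimidin-2-yl in place of pyrimidin-5-yl on an amine nitrogen. Three swaps at this nitrogen bear on it. They gave an at least 2.6-fold lower number from compound 1 to compound 2 (0.41 log units; beyond the scatter), then an at least 2.6-fold higher number from compound 2 to compound 3 (0.41 log units; beyond the scatter), and finally a step that the two limits leave unreadable from compound 1 to compound 3, so the ring matters. Even compound 2 , the only one with a measured number, is still weak at 11500 nM. Only a small move toward lower numbers is therefore expected, and the expected step is an at least 1.2-fold lower number from compound 3 to compound 4 (0.07 log units; that floor lies within the scatter) in this assay. For compound 4 the estimate is 25000 nM, with an expected range from 8000 nM to 60000 nM, and it may well report only a limit.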

Compound 4, half-maximal inhibitory concentration: 4760 nM
For compound 4 the middle estimate is 5.3-fold (0.72 log units) above the measured one, and the stated range ends above it.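

In this assay, among the compounds shown here, the 4-methylpyrimidin-2-yl ring goes beyond the only earlier measured number, with a 2.4-fold lower number from compound 2 to compound 4 (0.38 log units; beyond the scatter). Swapping the pyrimidin-5-yl for it leaves the counts of hetero atoms and hydrogen-bond acceptors unchanged, yet the read-out still shifts, with an at least 6.3-fold lower number from compound 3 to compound 4 (0.79 log units; beyond the scatter), and the comparison with the pyridin-2-yl ring gives an at least 6.3-fold lower number from compound 1 to compound 4 (0.79 log units; beyond the scatter). Both of these last two steps start from limits and not from numbers, so they are floors on the true size: the limit of > 30000 nM in this assay, at which 2 of the 4 values shown sit.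

The compounds shown leave open whether the methyl group or the pyrimidin-2-yl ring itself carries the change, and the plain pyrimidin-2-yl ring would separate the two. Also open, going by these compounds, is whether an ethyl or a methoxy group in place of that methyl would move the number further.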